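This account rests on a few compounds, and the source may have more. Where it says the series, first, only, none or still open, it means among the compounds named here.

Of the compounds shown here, three share one core and have been tested in a functional assay on the whole organism (lung, strain A/J) for inhibition, with Mus musculus as the target, with stated times of 1 h and 18 h, at a dose of 100 umol/kg by the oral route; on this read-out higher numbers stand for more inhibition at the one dose given (going by the name of the read-out) and lower numbers for less inhibition. Compound 1, with the structure `COc1ccc(/C=N/N(C)C(=O)c2ccccc2OC)cc1OC`, gives 52%. Compound 2, with the structure `COc1cccc(C(=O)N(C)/N=C/c2ccc(OC)c(OC)c2)c1`, gives 73%. Compound 3, with the structure `COc1ccc(/C=N/N(C)C(=O)c2ccc(O)cc2)cc1OC`, gives 65%. Among these three numbers compound 3 stands second highest: the step of a number 8 percentage points lower from compound 2 to compound 3 (within the scatter) lies within the scatter, while the step of a number 13 percentage points higher from compound 1 to compound 3 (beyond the scatter) lies beyond it, so compound 3 is clearly separated only from compound 1.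

Compound 4, with the structure `COc1ccc(/C=N/N(C)C(=O)c2ccc(Cl)cc2)cc1OC`, has not yet been measured. It differs from compound 3 in one place: chloro in place of hydroxy on an aromatic carbon. The measured steps that bear on this change are those that alter the same ring on the carbonyl carbon, namely a number 21 percentage points higher from compound 1 to compound 2 (beyond the scatter) and a number 13 percentage points higher from compound 1 to compound 3 (beyond the scatter), both modest, and a number 8 percentage points lower from compound 2 to compound 3 (within the scatter), which is within the scatter. Among the measured compounds shown here, no measured step swaps a hydroxy for a chloro, so the direction of the new step is not pinned down by these data. Given that changes on this ring have so far produced at most modest shifts, the expected step is a number 3 percentage points lower from compound 3 to compound 4 (within the scatter), most likely within the scatter. Compound 4 is therefore estimated to give 62%, with a range from 45% to 80%.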

Compound 4, a percentage reported as inhibition, in the whole organism at one dose (the size of the read-out at that dose, not a potency): 69%
Beside the measured number, compound 4's estimate is 7 percentage points below it; low and high end bracket the measured number.
By their numbers in this assay, from the lowest: compound 1; then compounds 3, 4 and 2 (each within the scatter of the next).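

In this assay, the step of a number 4 percentage points higher from compound 3 to compound 4 (within the scatter) shows that this place, para to a large group, accepts chloro as well as hydroxy, even though chloro brings 0 hydrogen-bond donors and 0 hydrogen-bond acceptors where hydroxy brought 1 of each, so the hydrogen-bond donor and acceptor of hydroxy are not needed to keep this read-out at this dose. The 4-chlorophenyl group also cannot be told apart from the 3-methoxyphenyl group, with a number 4 percentage points lower from compound 2 to compound 4 (within the scatter), whereas a number 17 percentage points higher from compound 1 to compound 4 (beyond the scatter) places compound 1 and its 2-methoxyphenyl group clearly apart, as it already was from compound 2 and compound 3, so all three other groups now stand clear of that one. Nothing available here explains why these groups behave alike or why the 2-methoxyphenyl group stands apart.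

Still open, from the compounds shown here alone, is what an amine or a carboxylic acid would do in this same place, since both groups tried here leave the number much the same. Going by these compounds, each compound also has a number at a single dose only, which says nothing about potency, and the rest of the shared core stays fixed, so the effect of a longer chain in place of the methyl on the nitrogen remains unknown.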